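The compounds below may be only part of what the source reports. "The series", "measured", "known", "first", "only" and "open" are said of these compounds alone.

Among the measured compounds shown here, in a functional assay on A549 cells (Homo sapiens) for antiproliferative activity, read by CCK-8 assay, with a stated time of 48 h (on this read-out higher numbers stand for weaker inhibition and lower numbers for stronger inhibition), compound 1 `O=C(Nc1ccccc1)c1cc(Oc2ccc(/C=C/c3ccccn3)cc2)ccn1` gives 19100 nM; compound 2 `COc1ccc(NC(=O)c2cc(Oc3ccc(/C=C/c4ccccn4)cc3)ccn2)cc1` gives 20000 nM, and the step of a 1.0-fold higher number from compound 1 to compound 2 (0.02 log units; within the scatter) leaves the two within the scatter of each other, so compound 1 stands level with its only neighbour. Compound 3 `O=C(NC1CC1)c1cc(Oc2ccc(/C=C/c3ccccn3)cc2)ccn1` carries cyclopropyl in place of phenyl on an amide-type nitrogen. For the measured compounds named here, no measured step covers this exchange; the single measured step at the group on the amide-type nitrogen was within the scatter and gives no direction. The step expected is therefore a 1.0-fold higher number from compound 1 to compound 3 (0.02 log units; within the scatter), nothing beyond the scatter. Compound 3 is expected to give about 20000 nM, between 6000 nM and 70000 nM.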

Compound 3, half-maximal inhibitory concentration: 17300 nM
Compound 3: middle estimate off by 1.2-fold (0.06 log units), on the high side; low and high end bracket the measured number.
By their numbers in this assay, from the lowest: compounds 3, 1 and 2 (each within the scatter of the next).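

Replacing the aromatic ring on the amide-type nitrogen with a non-aromatic one still moves nothing beyond the scatter: cyclopropyl in place of phenyl gives a 1.1-fold lower number from compound 1 to compound 3 (0.04 log units; within the scatter), and cyclopropyl in place of 4-methoxyphenyl gives a 1.2-fold lower number from compound 2 to compound 3 (0.06 log units; within the scatter). In this assay, this position therefore accepts a saturated three-membered ring as well as either aryl group, with all three compounds level. Nothing available explains this flat result.

From the compounds shown here alone, whether a longer alkyl chain, a carboxylic acid or an amine on this nitrogen would shift the number beyond the scatter remains open.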